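Chloro for hydrogen on the benzyl group across two cores

This account rests on a few compounds, and the source may have more. Where it says the series, first, only, none or still open, it means among the compounds named here.

Compound 1 `COC(=O)C1C(=O)C(C(=O)OC)[C@H](c2cccc([N+](=O)[O-])c2)N(Cc2ccccc2)[C@@H]1c1cccc([N+](=O)[O-])c1` and compound 2 `COC(=O)C1C(=O)C(C(=O)OC)[C@H](c2cccc([N+](=O)[O-])c2)N(Cc2ccc(Cl)cc2)[C@@H]1c1cccc([N+](=O)[O-])c1` share one core; compound 3 `COC(=O)C1=C(O)C[C@H](c2ccccn2)N(Cc2ccccc2)[C@@H]1c1ccccn1` and compound 4 `COC(=O)C1=C(O)C[C@H](c2ccccn2)N(Cc2ccc(Cl)cc2)[C@@H]1c1ccccn1` share another. The difference between the two cores is not broken down here.

In an ADME assay on J774.1 cells (Mus musculus) for cytotoxicity, with a stated time of 48 h (on this read-out lower numbers stand for an effect already at smaller amounts and higher numbers for an effect only at larger amounts of compound), compound 1 gives only a limit, > 100 uM. Compound 2 gives 46.6 uM in this assay. The change between them, (chloro in place of hydrogen on an aromatic carbon), made a step of an at least 2.1-fold lower number from compound 1 to compound 2 (0.33 log units; beyond the scatter); the step carries no exact size because of the limit of > 100 uM in this assay, at which 1 of the 3 values shown sits.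

Compound 3 gives 33.2 uM in this assay; set beside compound 2 the two numbers sit within the usual scatter.

Compound 4 carries the same change on the second core, (chloro in place of hydrogen on an aromatic carbon). Given that the chloro for hydrogen exchange gave an at least 2.1-fold lower number from compound 1 to compound 2 (0.33 log units; beyond the scatter), a step of similar direction, a 1.7-fold lower number from compound 3 to compound 4 (0.22 log units; within the scatter), is expected here, though with only one earlier instance the size remains uncertain. Compound 4 is therefore estimated at 20 uM in this assay, with a range of 10 uM to 40 uM.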

Compound 4, concentration for half-maximal effect: 32.8 uM
The estimate for compound 4 lay 1.6-fold (0.21 log units) below the measured number; low and high end bracket the measured number.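

On the core of compound 3, the change from benzyl to 4-chlorobenzyl gives a 1.0-fold lower number from compound 3 to compound 4 (0.01 log units; within the scatter) in this assay, and no step beyond the scatter appears on this core. The reading for compound 1, > 100 uM, is a limit of the assay and not a number, and these two pairs show neither that the change carries from one core to the other nor that its outcome depends on the core. The comparison stays unresolved: the same change on two cores in this assay, an at least 2.1-fold lower number (0.33 log units; beyond the scatter) from compound 1 to compound 2 and a 1.0-fold lower number (0.01 log units; within the scatter) from compound 3 to compound 4; the limit leaves it open whether they differ

Still open, going by these compounds, is how other groups in the place of chloro on the benzyl ring, such as a methoxy group, an amine or a carboxylic acid, would read in this assay on either core. Also open, on these data alone, is whether the 4-chlorobenzyl group would give a step beyond the scatter on a third core, or whether a longer chain in place of the benzyl group would change the reading.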